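A few compounds are considered here, and "the series" means these few. Any claim that something is new, unique, unknown or untested is made for them only; others in the source may bear on it.

Measured compounds in the series:

- compound 1 `Cc1ccccc1S(=O)(=O)NC(C1=CC(=O)c2c(O)ccc(O)c2C1=O)C(C)C`: 190 nM
- compound 2 `CC(C)C(NS(=O)(=O)c1ccc(Cl)cc1)C1=CC(=O)c2c(O)ccc(O)c2C1=O`: "not determined" (no result reported)
- compound 3 `CC(C)C(NS(=O)(=O)c1ccc(Br)cc1)C1=CC(=O)c2c(O)ccc(O)c2C1=O`: "not determined" (no result reported)

Only compound 1 carries a number in a functional assay on HL-60 cells (Homo sapiens) for cytotoxicity, read by MTT assay (a higher number here means a weaker inhibitor, a lower number a stronger inhibitor), where compound 1 gives 190 nM. Among the compounds with values here, compound 2 came back as "not determined" (no result reported) and compound 3 as "not determined" (no result reported), so compound 3 stands nowhere on the numbers: there is nothing to rank it against and no step from it to any other measured compound can be sized. Within the data shown here, the one number in hand, that of compound 1, is therefore the only anchor for this assay.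

The next compound, compound 4 `CC(C)C(NS(=O)(=O)c1ccccc1Br)C1=CC(=O)c2c(O)ccc(O)c2C1=O`, differs from compound 3 in one place: 2-bromophenyl in place of 4-bromophenyl on a sulfonyl sulfur. Compound 3 itself has no number, so the size of the step from compound 3 to compound 4 in this assay cannot be stated from data, in either direction; the expectation is simply that compound 4 lands in the same region as compound 1, which gives 190 nM, with wide uncertainty.

On that basis the half-maximal inhibitory concentration of compound 4 in this assay is estimated at 250 nM, with a plausible range from 70 nM to 900 nM.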

Compound 4, half-maximal inhibitory concentration: 340 nM
The estimate for compound 4 lay 1.4-fold (0.13 log units) below the measured number, and the stated range covers the measured number.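

In this assay, the change of bromo in place of methyl on an aromatic carbon gives a 1.8-fold higher number from compound 1 to compound 4 (0.25 log units; within the scatter), so this pair offers no basis for separating the two groups at this carbon of the aromatic ring on the sulfonyl sulfur. Within the data shown here, this is the first step that can be sized, and it rests on a single pair. Steps involving compound 2 or compound 3 cannot be read, so the exchange of 4-bromophenyl for 2-bromophenyl on the sulfonyl sulfur has no size, and the data cannot show whether the placing of the bromine matters. No measurement on hand bears on the reason for the size of the step from methyl to bromo.

The compounds shown leave open whether a methoxy group, an amine or a carboxylic acid on the same aromatic carbon would stay within the scatter of this pair. They also leave open how the series responds when the phenyl ring on the sulfonyl sulfur gives way to a longer chain or to a pyridine ring.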